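Hepatocyte clearance notes: fused bicyclic replacement on compound 2

This account rests on a few compounds, and the source may have more. Where it says the series, first, only, none or still open, it means among the compounds named here.

Measured so far:
compound 1 `CC(=O)N[C@@H]1CCC[C@H](C(=O)Nc2cc(-c3cnn4c3CCCC4)ccn2)C1` — 33 uL/min
compound 2 `CC(=O)N[C@@H]1CCC[C@H](C(=O)Nc2cc(-c3cnn(C)c3C)c(Cl)cn2)C1` — 10 uL/min

In an ADME assay on cells (Hepatocyte, Rattus norvegicus) for metabolic stability, using equilibrium dialysis (a higher number here means faster removal of the compound, a lower number slower removal), compound 2 gives 10 uL/min, the lowest of the two numbers; compound 1 gives 33 uL/min, a gap beyond the usual scatter. Compound 3 `CC(=O)N[C@@H]1CCC[C@H](C(=O)Nc2cc(-c3cnn4c3COCC4)c(Cl)cn2)C1` differs from compound 2 in one place: a group of 9 heavy atoms (6 carbon, 2 nitrogen, 1 oxygen; one five-membered aromatic ring with 2 hetero atoms, one six-membered non-aromatic ring with 2 hetero atoms) in place of a group of 7 heavy atoms (5 carbon, 2 nitrogen; one five-membered aromatic ring with 2 hetero atoms), on an aromatic carbon. For the measured compounds named here, no measured pair shows this exact change, so its size is uncertain. Given that compound 1, which also carries a fused bicyclic group, gives 33 uL/min, a small rise from compound 2 is expected, of a size near the scatter: a 1.5-fold higher number from compound 2 to compound 3 (0.18 log units; within the scatter). Compound 3 is estimated at 15 uL/min, within 7 uL/min to 32 uL/min.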

Compound 3, intrinsic clearance in a liver preparation (reported as CLH), per the amount of preparation that the assay uses: 18 uL/min
The estimate for compound 3 lay 1.2-fold (0.08 log units) below the measured number; the range from low to high includes it.
By their numbers in this assay, from the lowest: compounds 2, 3 and 1 (each within the scatter of the next, the first and the last beyond it).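

At this aromatic carbon, ortho to a chloro group, the fused group with its six-membered non-aromatic ring stands in place of 1,5-dimethyl-1H-pyrazol-4-yl, and this assay gives a 1.8-fold higher number from compound 2 to compound 3 (0.26 log units; within the scatter). The larger group therefore is not separated from the smaller one in this assay. Nothing at hand speaks to a cause for this result.

From the compounds shown here alone, the separate contribution of the ring oxygen remains open. So does the reading in this assay for an amine or a carboxylic acid on the fused ring, or for a fluoro group in place of the chloro group.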